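An inverted chain stereocentre after a large solubility step

A few compounds are considered here, and "the series" means these few. Any claim that something is new, unique, unknown or untested is made for them only; others in the source may bear on it.

Measured so far:
Compound 1 `C[C@H](CO)N1C[C@H](C)[C@@H](CN(C)Cc2ccc(Oc3ccccc3)cc2)Oc2c(NC(=O)c3ccncc3)cccc2C1=O` gives 2000 nM
Compound 2 `C[C@H](CO)N1C[C@H](C)[C@H](CN(C)Cc2ccc(Oc3ccccc3)cc2)Oc2c(NC(=O)c3ccncc3)cccc2C1=O` gives 98000 nM

In a physicochemical assay for solubility, in phosphate buffer (on this read-out higher numbers stand for higher solubility and lower numbers for lower solubility), compound 2 stands higher of the two at 98000 nM and compound 1 gives 2000 nM on the same scale. Compound 3 `C[C@H]1CN([C@@H](C)CO)C(=O)c2cccc(NC(=O)c3ccncc3)c2O[C@H]1CN(C)Cc1ccc(Oc2ccccc2)cc1` is the next to be read, and its relation to compound 2 is simple (the two compounds have the same atoms and bonds and differ only in configuration as drawn: 1 of 3 stereo elements differ; a stereocentre at a saturated chain carbon is drawn R in compound 2 and S in compound 3). Going by the values given here, one measured step bears on this change (a 49-fold higher number from compound 1 to compound 2 (1.69 log units; beyond the scatter)), and it goes with the fact that compounds 1 and 2 differ only in the configuration as drawn alone. That step shows how far a single inversion can move this read-out in the series. It concerns a saturated ring carbon, however, whereas compound 3 changes at a saturated chain carbon, so it offers a scale and not a direct precedent. Compound 2 already holds the top value (98000 nM), so a fall is expected to be likelier than a further rise, and a result within the scatter remains possible. The estimated step in this assay is a 2.8-fold lower number from compound 2 to compound 3 (0.45 log units; beyond the scatter) and points downward. The expected value for compound 3 is 35000 nM (range 5000 nM to 130000 nM).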

Compound 3, solubility: 93000 nM
Compound 3: the middle estimate sits 2.7-fold (0.42 log units) below what was measured; the measured number falls inside the stated range.
By their numbers in this assay, from the lowest: compound 1; then compounds 3 and 2 (each within the scatter of the next).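

In this assay, inverting the saturated chain carbon while the saturated ring carbon stays drawn R gives a 1.1-fold lower number from compound 2 to compound 3 (0.02 log units; within the scatter), so this chain position shows none of the large movement seen earlier at the ring carbon: the fact that compounds 2 and 3 differ only in the configuration as drawn The large step therefore does not belong to every stereocentre in this series, and compounds 2 and 3 stand together, separated from compound 1. That separation holds when both centres differ, with a 47-fold higher number from compound 1 to compound 3 (1.67 log units; beyond the scatter), a step of much the same size as a 49-fold higher number from compound 1 to compound 2 (1.69 log units; beyond the scatter), so the second inversion adds nothing that can be read on top of the ring-carbon change: the fact that compounds 1 and 3 differ only in the configuration as drawn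

As far as these compounds go, this reading of the chain carbon rests on one pair, with the ring carbon drawn R, and what the same inversion does when the ring carbon is drawn S remains open. It also remains open whether the chain carbon stays this silent once a carboxylic acid or a longer chain is carried on the shared core, and the compounds shown give no reason for the size of the ring-carbon step.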